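Small Steps in a Flat Series

The source may hold more compounds than are shown below. What is called first, only, known or untested is meant among the compounds shown, and "the series" means these compounds.

In a functional assay on RAW264.7 cells (Mus musculus) for inhibition, read by ELISA, with a stated time of 24 h (a higher number here means that more compound is needed for the effect, a lower number that less compound is needed), compound 1 `CC/C=C\C[C@H]1C(=O)C=C[C@H]1CC(=O)OCCCCC` gives 25000 nM and compound 2 `CC/C=C\C[C@H]1C(=O)C=C[C@H]1CC(=O)Oc1ccccc1` gives 33000 nM while compound 3 `CC/C=C\C[C@H]1C(=O)C=C[C@H]1CC(=O)OCc1ccccc1` gives 20000 nM and so stands within the scatter of both. Compound 4 `CC/C=C\C[C@H]1C(=O)C=C[C@H]1CC(=O)OCCOC` is still unmeasured and differs from compound 3 thus: methoxymethyl in place of phenyl on a saturated chain carbon bound to an oxygen next to a carbonyl group with methoxymethyl in place of phenyl on a saturated chain carbon bound to an oxygen next to a carbonyl group. For the measured compounds named here, three measured steps bear on this: a 1.3-fold higher number from compound 1 to compound 2 (0.12 log units; within the scatter) and a 1.3-fold lower number from compound 1 to compound 3 (0.10 log units; within the scatter) and a 1.7-fold lower number from compound 2 to compound 3 (0.22 log units; within the scatter) all lie within the scatter. None of them brings in methoxymethyl, so the data cover this group only indirectly. No step beyond the scatter is expected in this assay in either direction. The expected step is a 1.3-fold higher number from compound 3 to compound 4 (0.10 log units; within the scatter) and so stays within the scatter. Compound 4 is estimated at 25000 nM (expected range 12000 nM to 55000 nM).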

Compound 4, half-maximal effective concentration: 27000 nM
The estimate for compound 4 lay 1.1-fold (0.03 log units) below the measured number; the measured number falls inside the stated range.
By their numbers in this assay, from the lowest: compounds 3, 1, 4 and 2 (each within the scatter of the next).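

Putting methoxymethyl in place of phenyl on a saturated chain carbon bound to an oxygen next to a carbonyl group gives (a 1.4-fold higher number from compound 3 to compound 4 (0.13 log units; within the scatter)), so in this assay removing the aromatic ring and bringing in a chain oxygen leaves the number within the scatter. The same holds for 2-methoxyethyl in place of phenyl (a 1.2-fold lower number from compound 2 to compound 4 (0.09 log units; within the scatter)) and for methoxy in place of propyl (a 1.1-fold higher number from compound 1 to compound 4 (0.03 log units; within the scatter)). Nothing measured here accounts for this flatness. Still open, as far as these compounds go, is whether an amine or a carboxylic acid at this place would carry the number beyond the scatter.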